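The source may hold more compounds than are shown below. What is called first, only, known or untested is meant among the compounds shown, and "the series" means these compounds.

Measured so far in a functional assay on SK-MEL-5 cells (Homo sapiens) for inhibition, read by sulforhodamine B assay, with a stated time of 48 h; a lower number here means that less compound is tolerated, a higher number that more compound is tolerated: compound 1 `COc1ccc(-c2cc(/C=C/C(=O)c3ccc(N)cc3)[nH]n2)cc1` gives 30400 nM; compound 2 `COc1cc(-c2cc(/C=C/C(=O)c3ccc(N)cc3)[nH]n2)cc(OC)c1OC` gives 5690 nM; compound 3 `COc1ccc(C(=O)/C=C/c2cc(-c3cc(OC)c(OC)c(OC)c3)n[nH]2)cc1` gives 6100 nM.

Among these three numbers compound 2 has the lowest value. For the measured compounds named here, compound 3 sits within the scatter of it, as the single step on record shows: a 1.1-fold higher number from compound 2 to compound 3 (0.03 log units; within the scatter). Compound 1 stands beyond the scatter with a higher number, meaning the cells tolerate more of compound 1 than of compound 2.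

Compound 4 `COc1ccc(-c2cc(/C=C/C(=O)c3ccc(N)cc3)[nH]n2)cc1OC` differs from compound 2 in one place: hydrogen in place of methoxy on an aromatic carbon. Going by the values given here, no measured step repeats this exact change; the step from compound 2 to compound 3 touches a different part of the molecule. Compound 1 and compound 2 differ by two methoxy groups rather than one, and their two values show that the compound with fewer methoxy groups gave the higher number. Compound 4 is therefore expected to land between them, with a moderate rise: a 1.9-fold higher number from compound 2 to compound 4 (0.29 log units; within the scatter). The estimate for compound 4 in this assay is 11000 nM, with a range from 4000 nM to 30000 nM.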

Compound 4, concentration lethal to 50% of the cells: 36100 nM
For compound 4 the middle estimate is 3.3-fold (0.52 log units) below the measured one; measured number above the stated range.
By their numbers in this assay, from the lowest: compounds 2 and 3 (each within the scatter of the next); then compounds 1 and 4 (each within the scatter of the next).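

Removing this one methoxy, which sits ortho to a methoxy group and meta to a large group, gives a 6.3-fold higher number from compound 2 to compound 4 (0.80 log units; beyond the scatter) in this assay and so counts as a clear change. The step that adds a methoxy to the simpler ring, a 1.2-fold higher number from compound 1 to compound 4 (0.07 log units; within the scatter), shows no such difference, so among these compounds a methoxy matters on the ring that already carries two others but not on the ring that carries only one. Nothing available here explains this difference.

Going by these compounds, it remains open whether a hydroxyl group, an ethoxy group or a fluorine atom at this place would behave like methoxy or like hydrogen. On these data alone, it also remains open whether removing this methoxy from compound 3, with its second methoxy in place of the amino group, would produce a step of similar size.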